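Ring-closing the terminal amine: compound 3 to compound 4

The source may report more compounds than this note shows. Statements on the series, on what has been measured and on what is new or still open speak of the compounds shown alone.

Three compounds built on the shared core carry numbers in a functional assay on PC-3 cells (Homo sapiens) for antiproliferative activity, read by MTT assay, with a stated time of 72 h; a higher number here means a weaker inhibitor, a lower number a stronger inhibitor. Compound 1 `COc1cc2ncnc(N3CCc4ccccc43)c2cc1NC(=O)C=C(C)C` gives 7840 nM, compound 2 `COc1cc2ncnc(N3CCc4ccccc43)c2cc1NC(=O)/C=C/C(C)C` gives 6530 nM, and compound 3 `CCN(CC)C/C=C/C(=O)Nc1cc2c(N3CCc4ccccc43)ncnc2cc1OC` gives 3690 nM, the lowest of the three, though only the gap to compound 1 lies beyond the scatter. The steps among them are small: a 1.2-fold lower number from compound 1 to compound 2 (0.08 log units; within the scatter); a 2.1-fold lower number from compound 1 to compound 3 (0.33 log units; beyond the scatter); a 1.8-fold lower number from compound 2 to compound 3 (0.25 log units; within the scatter).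

Compound 4 `COc1cc2ncnc(N3CCc4ccccc43)c2cc1NC(=O)/C=C/CN1CCCC1` differs from compound 3 in one place: pyrrolidin-1-yl in place of diethylamino on a saturated chain carbon bound to a double-bonded chain carbon. Going by the values given here, no measured pair covers this exchange of one tertiary amine for another of the same size. The nearest comparison is the introduction of the (diethylamino)methyl group in place of isopropyl, a change of a larger kind that still stayed within the scatter. On that basis no step beyond the scatter is expected in this assay. Compound 4 is therefore expected near 3500 nM, within a range of 1500 nM to 8000 nM. The step this implies, a 1.1-fold lower number from compound 3 to compound 4 (0.02 log units; within the scatter), is expected to stay within the scatter.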

Compound 4, half-maximal inhibitory concentration: 2620 nM
For compound 4 the middle estimate is 1.3-fold (0.13 log units) above the measured one; low and high end bracket the measured number.
By their numbers in this assay, from the lowest: compounds 4, 3, 2 and 1 (each within the scatter of the next, the first and the last beyond it).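

Closing the diethylamino group into pyrrolidin-1-yl, on a saturated chain carbon bound to a double-bonded chain carbon and with the heavy-atom count unchanged, leaves the number in this assay within the scatter (a 1.4-fold lower number from compound 3 to compound 4 (0.15 log units; within the scatter)), so a ring is accommodated at this position. Compound 4 also separates from the amine-free compounds beyond the scatter (a 2.5-fold lower number from compound 2 to compound 4 (0.40 log units; beyond the scatter); a 3.0-fold lower number from compound 1 to compound 4 (0.48 log units; beyond the scatter)), whereas the diethylamino compound stayed within the scatter of compound 2 (a 1.8-fold lower number from compound 2 to compound 3 (0.25 log units; within the scatter)). Nothing available explains these steps.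

From the compounds shown here alone, whether the number holds with other cyclic amines, such as piperidin-1-yl or morpholin-4-yl, remains open. Also open, going by these compounds, is whether a primary amine or a longer chain between the double bond and the amine would keep compound 4's level.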